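The source may report more compounds than this note shows. Statements on the series, on what has been measured and on what is new or still open speak of the compounds shown alone.

Measured compounds:
Compound 1 `COC(=O)/C=C/c1cccc(N(Cc2ccc(/C=C/c3ccccc3F)cc2)C(=O)NC(C)C)c1`: 431 nM
Compound 2 `COC(=O)/C=C/c1cccc(N(Cc2ccc(-c3ccc(F)c(Cl)c3)cc2)C(=O)C2CCCCC2)c1`: 66 nM

In an assay on isolated protein with Bile acid receptor (Homo sapiens) as the target (on this read-out higher numbers stand for an effect only at larger amounts of compound and lower numbers for an effect already at smaller amounts), compound 2 gives 66 nM, the lowest of the two numbers available; compound 1 gives 431 nM in this assay, a gap that lies beyond the scatter. The two compounds differ in more than one place, so their values are only compared, not traced to one change.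

Compound 3 `CCOC(=O)/C=C/c1ccc(CN(C(=O)C2CCCCC2)c2cccc(/C=C/C(=O)OC)c2)cc1` is the untested compound that grows out of compound 2. The change is 2-(ethoxycarbonyl)ethenyl in place of 3-chloro-4-fluorophenyl on an aromatic carbon. Going by the values given here, no measured pair with this change exists, so the expectation rests on compound 2 alone. A step of moderate size toward a higher number is expected, beyond the scatter rather than within it, but not large.

For compound 3 in this assay the estimate is 220 nM, with a range from 60 nM to 800 nM; the expected step is a 3.3-fold higher number from compound 2 to compound 3 (0.52 log units; beyond the scatter).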

Compound 3, half-maximal effective concentration: > 1000 nM
Compound 3: only a limit was reported; the forecaster's own chance of this, stated with the estimate: 5%; at least 4.5-fold (0.65 log units) between middle value and limit.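

In this assay compound 3 gives > 1000 nM, which is a limit of the assay and not a number. Going by these compounds alone, the swap of 3-chloro-4-fluorophenyl for 2-(ethoxycarbonyl)ethenyl, on an aromatic carbon para to a large group, gives an at least 15-fold higher number from compound 2 to compound 3 (1.18 log units; beyond the scatter), the only step here that can be traced to one change, and it shows that the activity depends strongly on what this position carries. Its full size stays unknown, and the reading is bounded only by the limit: the limit of > 1000 nM in this assay, at which 1 of the 3 values shown sits.

The change removes an aromatic ring and brings in 2 hydrogen-bond acceptors at once, so these compounds leave open which of the two matters. A plain phenyl, a pyridine or a carboxylic acid in place of the ethyl ester would each bear on that question.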